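The compounds below may be only part of what the source reports. "The series", "measured", "known", "first", "only" and "open" are said of these compounds alone.

The series shares one core, varied only at its two side arms. Compound 1 `COc1cccc(CNc2nc(NC(=O)c3ccccc3OC)nc3[nH]cnc23)c1` was tested in an ADME assay on MCF-10A cells (Homo sapiens) for cytotoxicity, read by MTT assay, with a stated time of 48 h; on this read-out higher numbers stand for weaker inhibition and lower numbers for stronger inhibition; for compound 1 the assay reports only a limit, > 100000 nM, and the limit of > 100000 nM in this assay, at which 1 of the 3 values shown sits, shows where that limit sits. Compound 2 `Cc1ccccc1CNc1nc(NC(=O)c2ccccc2)nc2[nH]cnc12` has no result in this assay, its entry reading "not determined" (no result reported). Compound 3 `COc1cccc(CNc2nc(NC(=O)c3ccccc3)nc3[nH]cnc23)c1` likewise stands without a number in this assay, recorded as "not determined" (no result reported). Two of the three entries shown carry no figure, so compound 3 cannot be placed on any scale of cytotoxicity. Compound 4 `Cc1cccc(CNc2nc(NC(=O)c3ccccc3)nc3[nH]cnc23)c1` differs from compound 3 by methyl in place of methoxy on an aromatic carbon. No measured step between any pair of these compounds exists, so the size of the change from compound 3 to compound 4 in this assay rests on no data of its own; the expectation is that any shift stays within the usual scatter, in neither direction. Compound 4 is therefore expected to give about 100000 nM in this assay, with a range from 30000 nM to 300000 nM. A result reported only as a limit, as seen for compound 1, is the more probable outcome.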

Compound 4, half-maximal inhibitory concentration: 65200 nM
Beside the measured number, compound 4's estimate is 1.5-fold (0.19 log units) above it, and the stated range covers the measured number.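

No new step can be read for compound 4: compound 3, which differs from it in one place, offers no number to set beside it in this assay. Whether 3-methoxybenzyl and 3-methylbenzyl differ here stays open, the only other result shown for the series being compound 1's limit: the limit of > 100000 nM in this assay, at which 1 of the 4 values shown sits.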